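This account rests on a few compounds, and the source may have more. Where it says the series, first, only, none or still open, it means among the compounds named here.

Working notes on the series. Two measured compounds share the core and differ in the amine side chains and in the aryl group on the ring nitrogen: compound 1 `CCCCN(CC)c1cc(C)nc2c1NC(=O)CN2c1ccc(C)cc1Cl` and compound 2 `CCCN(CCC)c1cc(C)nc2c1NC(=O)CN2c1ccc(C(C)C)cc1Br`. In an assay on HEK-293T cells for displacement of a labelled ligand from corticotropin-releasing factor receptor 1 (Homo sapiens), read by scintillation counting, with a stated time of 2 h (on this read-out lower numbers stand for stronger inhibition and higher numbers for weaker inhibition), compound 1 gives 4.4 nM; compound 2 gives 3.1 nM in this assay. Compound 1 stands at the higher of the two numbers, with a gap to compound 2 that lies within the scatter.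

Compound 3 `CCCCN(CC)c1cc(C)nc2c1NC(=O)CN2c1ccc(Cl)cc1Cl` is the next entry, not yet measured in this assay. It differs from compound 1 by one change: chloro in place of methyl on an aromatic carbon. Within the data shown here, no measured pair carries this change, so no step can be read from the data for it.

The expectation for compound 3 is a step of a 1.0-fold higher number from compound 1 to compound 3 (0.01 log units; within the scatter), no shift beyond the scatter in either direction. Compound 3 is estimated at 4.5 nM in this assay, with a range from 1.5 nM to 13 nM.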

Compound 3, inhibition constant: 3.4 nM
Beside the measured number, compound 3's estimate is 1.3-fold (0.12 log units) above it; low and high end bracket the measured number.
By their numbers in this assay, from the lowest: compounds 2, 3 and 1 (each within the scatter of the next).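

Chloro in place of methyl on this aromatic carbon, meta to a chloro group and para to a large group, gives the first step that can be read in the series: in this assay, going from 2-chloro-4-methylphenyl to 2,4-dichlorophenyl gives a 1.3-fold lower number from compound 1 to compound 3 (0.11 log units; within the scatter), so this one-atom exchange on the core of compound 1 leaves no shift beyond the scatter. This position therefore accepts either methyl or chloro in this pair, a point that the comparison of compounds 1 and 2, which differ in more than one place, could not show. No measurement bears on why the two groups read alike.

From the compounds shown here alone, whether a methoxy group, a trifluoromethyl group or a carboxylic acid on this carbon would stay within the same range remains open. So does whether the same exchange reads alike with the amine side chain of compound 2.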